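Chloro to hydrogen on the aryl ring of compound 2

This account rests on a few compounds, and the source may have more. Where it says the series, first, only, none or still open, it means among the compounds named here.

Measured compounds:
Compound 1 `COc1ccccc1N1CCn2c1n[nH]c(=O)c2=O` gives 1%.
Compound 2 `N=c1c(=O)[nH]nc2n1CCN2c1ccccc1Cl` gives 0%.
Compound 3 `COc1ccc(N2CCN/C2=N\N)cc1` gives 17%.

In a functional assay on T47D cells (Homo sapiens) for cytotoxicity, with a stated time of 72 h, tested at 10 ug/mL (on this read-out lower numbers stand for a weaker effect and higher numbers for a stronger effect at the one concentration tested), compound 2 stands lowest of the three numbers. Its nearest neighbour is compound 1, whose value lies within the scatter of it; compound 3 lies furthest, beyond the scatter. Compound 4 `N=c1c(=O)[nH]nc2n1CCN2c1ccccc1` has not yet been measured. It differs from compound 2 by hydrogen in place of chloro on an aromatic carbon. Within the data shown here, no pair of measured compounds differs in a single place, so no measured step guides this change. Given that compound 2 gives 0% and compound 1, which shares its core, gives 1%, compound 4 is expected to show no step beyond the scatter, an estimated change of a number 3 percentage points higher from compound 2 to compound 4 (within the scatter). Compound 4 is thus estimated at 3%, within 0% to 12%.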

Compound 4, a percentage reported as inhibition, at one concentration (the size of the read-out at that concentration, not a potency): 0%
Compound 4: middle estimate off by 3 percentage points, on the high side; the range from low to high includes it.
By their numbers in this assay, from the lowest: compounds 2, 4 and 1 (each within the scatter of the next); then compound 3.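

In this assay, among these compounds, hydrogen in place of chloro on an aromatic carbon, ortho to a large group, gives no change at the digits printed from compound 2 to compound 4 (within the scatter), the first step in this set that changes a single place. It shows that swapping the chloro for hydrogen at this position does not move the read-out, although a step starting from so little effect could hardly reveal a loss. As far as these compounds go, whether another group here, such as an amine or a carboxylic acid, would raise the read-out stays open. Nothing at hand explains this flat step.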